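The compounds below may be only part of what the source reports. "The series", "measured", "known", "first", "only" and "open" are said of these compounds alone.

Measured in a functional assay on MGC-803 cells (Homo sapiens) for antiproliferative activity, read by MTT assay, with a stated time of 72 h; on this read-out lower numbers stand for stronger inhibition and higher numbers for weaker inhibition:
Compound 1 `CCCSc1nc(N/N=C/c2ccccc2Cl)c2nnn(Cc3ccccc3)c2n1` gives 10900 nM.
Compound 2 `CCCSc1nc(N/N=C/c2cccc(Cl)c2)c2nnn(Cc3ccccc3)c2n1` gives > 64000 nM, a limit of the assay.
Compound 3 `CCCSc1nc(N/N=C/c2cccs2)c2nnn(Cc3ccccc3)c2n1` gives > 64000 nM, a limit of the assay.

Compound 3 therefore stands at the limit of > 64000 nM in this assay, at which 2 of the 3 values shown sit, and nothing more exact is known for it. The step of an at least 5.8-fold higher number from compound 1 to compound 3 (0.76 log units; beyond the scatter) shows that exchanging 2-chlorophenyl for thiophen-2-yl weakened the compound by at least a modest amount, while a step that the two limits leave unreadable from compound 2 to compound 3 cannot be read. Compound 4 `CCCSc1nc(N/N=C/c2c(O)ccc3ccccc23)c2nnn(Cc3ccccc3)c2n1` differs from compound 3 in this way: 2-hydroxynaphthalen-1-yl in place of thiophen-2-yl on a carbon with a double bond to nitrogen. Going by the values given here, no measured step covers this exact exchange; only the loss seen from compound 1 to compound 3 suggests that leaving thiophen-2-yl may recover activity in this assay. Compound 4 is expected at 15000 nM (range 4000 nM to 64000 nM), and the estimated step is an at least 4.2-fold lower number from compound 3 to compound 4 (0.63 log units; beyond the scatter).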

Compound 4, half-maximal inhibitory concentration: 3710 nM
For compound 4 the middle estimate is 4.0-fold (0.61 log units) above the measured one; the measured number lies below the stated range.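

At this position, on a carbon with a double bond to nitrogen, 2-hydroxynaphthalen-1-yl is the first group shown to improve on 2-chlorophenyl, with a 2.9-fold lower number from compound 1 to compound 4 (0.47 log units; beyond the scatter). Measured against the other two groups, the exchange gives an at least 17-fold lower number from compound 3 to compound 4 (1.23 log units; beyond the scatter) and an at least 17-fold lower number from compound 2 to compound 4 (1.23 log units; beyond the scatter). Both of these steps start from a limit: the limit of > 64000 nM in this assay, at which 2 of the 4 values shown sit.

The compounds shown leave open whether the hydroxy group or the naphthalene rings account for this gain. A plain naphthyl group, or a methoxy group in place of the hydroxy, would separate the two.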